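This account rests on a few compounds, and the source may have more. Where it says the series, first, only, none or still open, it means among the compounds named here.

Measured so far:
compound 1 `CC(C)=CCOc1cc(=O)n(CCCO)c2c1CC(CC=C(C)C)C(C)(C)C2` — 20.7% in a functional assay on PANC-1 cells (Homo sapiens) for inhibition, read by MTT assay, with a stated time of 24 h, tested at 10 uM; a lower number here means less inhibition, a higher number more inhibition at the concentration tested (going by the name of the read-out)
compound 2 `CC(C)=CCC1Cc2c(OCCCNC(=O)c3ccc([N+](=O)[O-])cc3)cc(=O)n(CCCO)c2CC1(C)C` — 49.9% in this assay

Of the two numbers, compound 2 stands highest: compound 1 comes out lower, and that gap lies beyond the usual scatter of this assay. Compound 3 `CC(C)=CCC1Cc2c(OCCCOc3ccc([N+](=O)[O-])cc3)cc(=O)n(CCCO)c2CC1(C)C` is the next compound and has not yet been measured. It differs from compound 2 in a single place: 4-nitrophenoxy in place of ((4-nitrophenyl)carbonyl)amino on a saturated chain carbon, three bonds along the chain from an oxygen on an aromatic ring. So the ((4-nitrophenyl)carbonyl)amino group leaves and a 4-nitrophenoxy group enters, on a saturated chain carbon, three bonds along the chain from an oxygen on an aromatic ring. For the measured compounds named here, no measured pair shows this exact change, so its effect is unknown. Starting from compound 2 with 49.9%, a modest fall is expected, though a result within the scatter cannot be ruled out. The step of a number 9.9 percentage points lower from compound 2 to compound 3 (within the scatter) is expected to be small to moderate and downward. Compound 3 is therefore estimated at 40%, in the range 18% to 62%.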

Compound 3, a percentage reported as inhibition, at one concentration (the size of the read-out at that concentration, not a potency): 47.5%
Compound 3: the middle estimate sits 7.5 percentage points below what was measured, within the range that was stated.
By their numbers in this assay, from the lowest: compound 1; then compounds 3 and 2 (each within the scatter of the next).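

In this assay, 4-nitrophenoxy in place of ((4-nitrophenyl)carbonyl)amino gives a number 2.4 percentage points lower from compound 2 to compound 3 (within the scatter), so this assay cannot tell the amide link from the ether link at this position, even though the change takes away the one hydrogen-bond donor of the leaving group. The step of 2-(4-nitrophenoxy)ethyl in place of 2-methylprop-1-en-1-yl gives a number 26.8 percentage points higher from compound 1 to compound 3 (beyond the scatter), which shows that the higher reading seen for compound 2 does not require the amide link. No measurement at hand gives a reason for either result.

Going by these compounds, both compound 2 and compound 3 carry a nitro group on the ring, so its share in these readings stays open. A plain phenoxy group, a 4-aminophenoxy group or a longer chain could test this position further.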